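Series notes: from compound 1 to compound 4

A few compounds are considered here, and "the series" means these few. Any claim that something is new, unique, unknown or untested is made for them only; others in the source may bear on it.

For the measured compounds named here, compound 1 `CC[C@H](CCCc1cccnc1)NC(=O)/C=C/C=C(c1ccc(OC)cc1)c1ccc(OC)cc1` holds the lowest of the three numbers measured so far. In an assay (Canis lupus familiaris) for binding affinity to platelet-activating factor receptor (Homo sapiens), read by radioligand binding (a higher number here means a weaker inhibitor, a lower number a stronger inhibitor), compound 1 gives 120 nM. Compound 2 `Cc1ccc(C(=C/C=C/C(=O)N[C@H](C)CCCc2cccnc2)c2ccc(C)cc2)cc1` gives 250 nM in this assay, and compound 3 `O=C(C=C(c1ccccc1)c1ccccc1)NCCCCc1cccnc1` gives 450 nM; both gaps to compound 1 lie beyond the scatter, so compound 1 is the strongest inhibitor of the three. Compound 4 `COc1ccc(C(=C/C=C/C(=O)NCCCCc2cccnc2)c2ccc(OC)cc2)cc1` differs from compound 1 by hydrogen in place of ethyl on a saturated chain carbon bound to an amide-type nitrogen and a saturated chain carbon. Going by the values given here, no measured pair shows this change on its own, and compound 3, which also lacks a branch, differs from compound 1 elsewhere as well, so no direct reading is possible. A modest weakening is expected, with the step from compound 1 to compound 4 estimated at a 2.1-fold higher number from compound 1 to compound 4 (0.32 log units; beyond the scatter). Compound 4 is expected to give about 250 nM in this assay, within a range from 100 nM to 700 nM.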

Compound 4, half-maximal inhibitory concentration: 25 nM
For compound 4 the middle estimate is 10-fold (1.00 log units) above the measured one; the whole stated range lies above it.
By their numbers in this assay, from the lowest: compound 4; then compound 1; then compounds 2 and 3 (each within the scatter of the next).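

For the compounds shown here, the step of a 4.8-fold lower number from compound 1 to compound 4 (0.68 log units; beyond the scatter) in this assay is the first change read in one place alone. Hydrogen in place of ethyl on this saturated chain carbon strengthens inhibition, so the ethyl branch is not needed for inhibition on this core, and the unbranched chain of compound 4 gives the lowest number so far. No data at hand account for the gain.

Still open, going by these compounds, is how a propyl or a hydroxymethyl group on this carbon would read, and whether the gain carries over to other cores.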